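This account rests on a few compounds, and the source may have more. Where it says the series, first, only, none or still open, it means among the compounds named here.

Compound 1 `CC(CSc1cc(C(F)(F)F)cc(C(F)(F)F)c1)C(=O)Nc1ccc(C#N)cc1C(F)(F)F` and compound 2 `CC(CSc1cc(C(F)(F)F)cc(C(F)(F)F)c1)C(=O)Nc1ccc([N+](=O)[O-])cc1C(F)(F)F` share one core and differ at a single aromatic carbon. In a functional assay on LNCaP cells (Homo sapiens) for antiproliferative activity, read by MTT assay, with a stated time of 96 h (a lower number here means a stronger inhibitor, a higher number a weaker inhibitor), compound 1 gives 4570 nM, and compound 2 gives 43700 nM. The change between them is nitro in place of cyano on an aromatic carbon, and it produced a 9.6-fold higher number from compound 1 to compound 2 (0.98 log units; beyond the scatter).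

Compound 3 `CC(CS(=O)(=O)c1cc(C(F)(F)F)cc(C(F)(F)F)c1)C(=O)Nc1ccc(C#N)c(C(F)(F)F)c1` has a different core; how the core of compound 3 differs from the core of compound 1 is not broken down here. In this assay compound 3 gives 6160 nM, and the values of compound 3 and compound 1 lie within the scatter of each other.

Compound 4 `CC(CS(=O)(=O)c1cc(C(F)(F)F)cc(C(F)(F)F)c1)C(=O)Nc1ccc([N+](=O)[O-])c(C(F)(F)F)c1` has not yet been measured. It differs from compound 3 by nitro in place of cyano on an aromatic carbon. This is the same kind of change as that from compound 1 to compound 2, but not the same: in compound 2 the nitro sits meta to a trifluoromethyl group, whereas in compound 4 it sits ortho to a trifluoromethyl group, and the two cores differ as well.

Among the measured compounds shown here, with only one earlier example of this kind of change, the expectation for compound 4 rests on the step from compound 1 to compound 2: because compound 2 showed a 9.6-fold higher number from compound 1 to compound 2 (0.98 log units; beyond the scatter), a step of similar direction, a 6.5-fold higher number from compound 3 to compound 4 (0.81 log units; beyond the scatter), is expected from compound 3 to compound 4, though the different core and surroundings leave the size uncertain. In this assay compound 4 is therefore estimated at 40000 nM, expected to fall between 12000 nM and 130000 nM.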

Compound 4, half-maximal inhibitory concentration: 12200 nM
The estimate for compound 4 lay 3.3-fold (0.52 log units) above the measured number; the measured number falls inside the stated range.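

In this assay, putting nitro in place of cyano on the second core gives a 2.0-fold higher number from compound 3 to compound 4 (0.30 log units; within the scatter), so on this core the swap cannot be told apart from ordinary variation between repeated measurements. The size of the step therefore did not carry over from one core to the other, and the large penalty seen on the first core cannot simply be assumed on the second: the same change on two cores in this assay, a 9.6-fold higher number (0.98 log units; beyond the scatter) from compound 1 to compound 2 and a 2.0-fold higher number (0.30 log units; within the scatter) from compound 3 to compound 4, 4.8-fold (0.68 log units) apart, beyond the scatter of two such steps This does not show which feature of the cores goes with the difference, since the two cores are not broken down into single changes here and the nitro group sits in different surroundings on each, nor does a pair of examples give a rule for the rest of the series.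

The compounds shown leave open how the step would behave on a core that differs from the core of compound 1 or the core of compound 3 in only one place, which could tie the difference to a single feature. They also leave open what an amine, a carboxylic acid or a chlorine atom would do at the same aromatic carbon on either core.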